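Aryl swap on two analogues that both sit at the assay limit

This account rests on a few compounds, and the source may have more. Where it says the series, first, only, none or still open, it means among the compounds named here.

Compound 1 `COc1cc(-c2ccc3ncn(-c4cc(OC)c(OC)c(OC)c4)c3c2)cc(OC)c1OC` and compound 2 `COc1cc(-n2cnc3ccc(-c4ccccc4Cl)cc32)cc(OC)c1OC` share one core. In a functional assay on A549 cells (Homo sapiens) for antiproliferative activity, read by MTT assay, with a stated time of 72 h (a lower number here means a stronger inhibitor, a higher number a weaker inhibitor), compound 1 gives only a limit, > 10000 nM. In this assay compound 2 likewise gives only a limit, > 10000 nM. Both readings rest on (the limit of > 10000 nM in this assay, at which 2 of the 2 values shown sit). Compound 3 `COc1cc(-n2cnc3ccc(-c4ccc(C)cc4)cc32)cc(OC)c1OC` differs from compound 2 by 4-methylphenyl in place of 2-chlorophenyl on an aromatic carbon. Among the compounds with values here, no measured step covers this change, and with both known values at the limit no direction can be read from them. The expected step that the limit leaves unreadable from compound 2 to compound 3 is therefore none beyond the scatter. For compound 3 the estimate in this assay is 15000 nM, within 4000 nM to 60000 nM, most probably reported again only as a limit.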

Compound 3, half-maximal inhibitory concentration: 1940 nM
Compound 3: middle estimate off by 7.7-fold (0.89 log units), on the high side; measured number outside the range, below it.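

This aromatic carbon can carry a group that gives a measurable value: in this assay, 4-methylphenyl in place of 2-chlorophenyl gives an at least 5.1-fold lower number from compound 2 to compound 3 (0.71 log units; beyond the scatter). Compound 3 is the only compound shown with a number rather than a limit, so the aryl group here changes the result while the rest of the structure stays fixed. The full size of the step remains unknown, since only one end is a number: the limit of > 10000 nM in this assay, at which 2 of the 3 values shown sit.

Going by these compounds, what 4-chlorophenyl or 2-methylphenyl would give here remains open, so the identity of the substituent and its place on the phenyl ring cannot be told apart. Also open, on these data alone, is how a phenyl ring bearing an amine or a carboxylic acid would read.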